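The source may report more compounds than this note shows. Statements on the series, on what has been measured and on what is new or still open speak of the compounds shown alone.

Working notes on the series. Among the measured compounds shown here, compound 1 `Cc1nc(N)sc1CCCN/C(N)=N/C(=O)NCc1ccco1` is one of two compounds measured in a functional assay on Right cardiac atrium for agonist activity at histamine H2 receptor (Cavia porcellus), with a stated time of 30 min, in the presence of a further agent that is not named here; a higher number here means a larger maximal response, a lower number a smaller maximal response; compound 1 gives 0.58, the lower of the two numbers, while compound 2 `CCC(NC(=O)/N=C(\N)NCCCc1sc(N)nc1C)c1ccccc1` gives 0.93 in this assay, a gap that lies beyond the usual scatter. Compound 3 `Cc1nc(N)sc1CCCN/C(N)=N/C(=O)NC(C)c1cccs1` is not yet measured in this assay. It differs from compound 1 in one place: 1-(thiophen-2-yl)ethyl in place of (furan-2-yl)methyl on an amide-type nitrogen. For the measured compounds named here, no step between two measured compounds is available for this change, so the expectation rests on the two values shown. Compound 2, the compound with the higher value, carries a branched group on the amide-type nitrogen, and compound 3 likewise carries a branched group there, so a rise from compound 1 to compound 3 is expected in this assay, though its size is uncertain and could stay within the scatter. For compound 3 in this assay the estimate is 0.75, in the range 0.55 to 0.95, which would mean an expected step of a number 0.17 higher from compound 1 to compound 3 (beyond the scatter).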

Compound 3, intrinsic activity: the largest response reached, as a fraction of the reference agonist's: 0.88
For compound 3 the middle estimate is 0.13 below the measured one, and the stated range covers the measured number.
By their numbers in this assay, from the lowest: compound 1; then compounds 3 and 2 (each within the scatter of the next).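

In this assay the group on the amide-type nitrogen clearly moves the maximal response: 1-(thiophen-2-yl)ethyl in place of (furan-2-yl)methyl gives a number 0.30 higher from compound 1 to compound 3 (beyond the scatter) in this series. With this change, compound 3 at 0.88 and compound 2 at 0.93 lie within the scatter of each other, so two different branched groups at this position give indistinguishable values here. Nothing available accounts for the size of the step.

The change swaps the ring and adds a branch at once, so the share of each remains unresolved; 1-(furan-2-yl)ethyl and (thiophen-2-yl)methyl on the same nitrogen would separate the two. Going by these compounds, whether a longer chain at the branch point holds the response at this level also remains open.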